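A Fluorine Added Where Only Hydrogen Stood

This account rests on a few compounds, and the source may have more. Where it says the series, first, only, none or still open, it means among the compounds named here.

Of the compounds shown here, three sharing one core have been tested in a functional assay on SGC-7901 cells (Homo sapiens) for antiproliferative activity, read by MTT assay, with a stated time of 24 h; on this read-out lower numbers stand for stronger inhibition and higher numbers for weaker inhibition. Compound 1 `Cc1ccccc1-n1cc(-c2ccccc2NS(=O)(=O)c2c[nH]c(=O)[nH]c2=O)nn1` gives 9570 nM. Compound 2 `O=c1[nH]cc(S(=O)(=O)Nc2ccccc2-c2cn(-c3ccccc3F)nn2)c(=O)[nH]1` gives 10800 nM, and the step of a 1.1-fold higher number from compound 1 to compound 2 (0.05 log units; within the scatter) shows that swapping those two groups leaves the read-out essentially unchanged. Compound 3 `O=c1[nH]cc(S(=O)(=O)Nc2cccc(-c3cn(-c4ccccc4)nn3)c2)c(=O)[nH]1` gives 17200 nM; its number lies within the scatter of both compound 1 and compound 2, so the three cannot be told apart with confidence.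

Compound 4 `O=c1[nH]cc(S(=O)(=O)Nc2cccc(-c3cn(-c4cccc(F)c4)nn3)c2)c(=O)[nH]1` is not yet measured. It differs from compound 3 only by fluoro in place of hydrogen on an aromatic carbon, sitting on an aromatic carbon of a six-membered aromatic ring of carbon only, meta to a large group. For the measured compounds named here, the one measured step that touches a small group on that same ring, from compound 1 to compound 2, stayed within the scatter, and nothing else bears on this change. The expected step of a 1.1-fold lower number from compound 3 to compound 4 (0.06 log units; within the scatter) is therefore none beyond the scatter. Compound 4 is estimated at 15000 nM, with a range from 6000 nM to 40000 nM.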

Compound 4, half-maximal inhibitory concentration: > 20000 nM
Compound 4 was reported as a limit (the forecaster's own chance of this, stated with the estimate: 10%); at least 1.3-fold (0.12 log units) between middle value and limit.
By their numbers in this assay, from the lowest: compounds 1, 2 and 3 (each within the scatter of the next). At a limit, above all of these: compound 4.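

In this assay compound 4 gives > 20000 nM as its reading, and that is a limit of the assay, not a number. The result gives an at least 1.1-fold higher number from compound 3 to compound 4 (0.06 log units; that floor lies within the scatter) and no upper end, so the real step from fluoro in place of hydrogen could be small or large. For this place on the ring, meta to a large group, going from phenyl to 3-fluorophenyl gives no sign of stronger inhibition, yet the size of the change stays unknown: the limit of > 20000 nM in this assay, at which 1 of the 4 values shown sits.

The compounds shown leave open how a different group at this same place, such as methyl, methoxy, an amine or a carboxylic acid, would read. They also leave open whether fluoro elsewhere on this ring would give a measurable number rather than a limit.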